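The compounds below may be only part of what the source reports. "The series", "measured", "known", "first", "only" and "open" are said of these compounds alone.

Measured compounds:
compound 1 `O=c1[nH]c(=O)n(C2C[C@@H](O)[C@@H](CO)O2)nc1/C=C/Br`: 355 ug/mL
compound 2 `CS/C=C/c1nn(C2C[C@@H](O)[C@@H](CO)O2)c(=O)[nH]c1=O`: 420 ug/mL

In a functional assay on Vero cells (Chlorocebus sabaeus) for cytotoxicity (a higher number here means a weaker inhibitor, a lower number a stronger inhibitor), compound 2 gives 420 ug/mL, the higher of the two numbers; the step of a 1.2-fold higher number from compound 1 to compound 2 (0.07 log units; within the scatter) lies within the scatter, so the two compounds are not separated here.

Compound 3 `O=c1[nH]c(=O)n(C2C[C@@H](O)[C@@H](CO)O2)nc1C=C(Br)Br` differs from compound 2 by 2,2-dibromoethenyl in place of 2-(methylsulfanyl)ethenyl on an aromatic carbon. Among the measured compounds shown here, the only step in hand, a 1.2-fold higher number from compound 1 to compound 2 (0.07 log units; within the scatter), exchanges methylsulfanyl and bromo on this chain without moving the number beyond the scatter; for a second bromine on the chain no step exists. Compound 3 is therefore expected to give no step beyond the scatter, a 1.1-fold lower number from compound 2 to compound 3 (0.04 log units; within the scatter). The estimate for compound 3 in this assay is 380 ug/mL, with a range of 180 ug/mL to 800 ug/mL.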

Compound 3, concentration for 50% inhibition: > 500 ug/mL
Compound 3: a limit, no number; the forecaster's own chance of this, stated with the estimate: 20%; at least 1.3-fold (0.11 log units) between middle value and limit.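

In this assay compound 3 reads as a limit and not a number, > 500 ug/mL: the limit of > 500 ug/mL in this assay, at which 1 of the 3 values shown sits. On this aromatic carbon, 2,2-dibromoethenyl gives an at least 1.1-fold higher number from compound 2 to compound 3 (0.07 log units; that floor lies within the scatter) in place of 2-(methylsulfanyl)ethenyl, and an at least 1.4-fold higher number from compound 1 to compound 3 (0.14 log units; that floor lies within the scatter) in place of 2-bromoethenyl. Neither floor separates compound 3 from the other two, so the second bromine on the chain has no measured size of effect. Open, from the compounds shown here alone, is whether an amine or a carboxylic acid on this chain, or a longer chain, would give a number clearly lower than those of compound 1 and compound 2.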